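This account rests on a few compounds, and the source may have more. Where it says the series, first, only, none or still open, it means among the compounds named here.

Measured compounds:
compound 1 `CCCCc1cnc(C(=O)/C=C/c2ccccc2O)cn1` — 184000 nM
compound 2 `CCCCc1cnc(C(=O)/C=C/c2ccc(O)cc2)cn1` — 306000 nM
compound 3 `CCCCCCCCSc1cc(C(N)=S)ccn1` — 72000 nM

All three numbers come from a functional assay on the whole organism for inhibition, with Spinacia oleracea as the target, read by spectrophotometry, with a stated time of 4 h; a lower number here means a stronger inhibitor, a higher number a weaker inhibitor. Compound 2 sits at the upper end of the numbers shown, but compound 1 cannot be told apart from it: the step of a 1.7-fold higher number from compound 1 to compound 2 (0.22 log units; within the scatter) stays within the scatter. Among the measured compounds shown here, compound 3 differs from both in the core and the substituents, and its number lies beyond the scatter, lower than that of compound 2; no single-point step connects it to the others.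

Compound 4 `CC(C)Cc1cnc(C(=O)/C=C/c2ccc(O)cc2)cn1` is not yet measured in this assay. Against compound 2 it carries isopropyl in place of propyl on a saturated chain carbon bound to an aromatic carbon. For the measured compounds named here, none of the measured steps touches this chain: the only step with one change, from compound 1 to compound 2, moves the hydroxyl on the phenyl ring and says nothing about the chain on the core. Without a bearing step, the expectation is no step beyond the scatter in this assay, in either direction.

Compound 4 is therefore expected at 300000 nM, within 100000 nM to 900000 nM. The step this estimate means, a 1.0-fold lower number from compound 2 to compound 4 (0.01 log units; within the scatter), is expected to stay within the scatter.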

Compound 4, half-maximal inhibitory concentration: 235000 nM
Beside the measured number, compound 4's estimate is 1.3-fold (0.11 log units) above it; the measured number falls inside the stated range.
By their numbers in this assay, from the lowest: compound 3; then compounds 1, 4 and 2 (each within the scatter of the next).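

Among the compounds shown here, the chain on the core is now touched for the first time: in this assay, isopropyl in place of propyl on a saturated chain carbon bound to an aromatic carbon gives a 1.3-fold lower number from compound 2 to compound 4 (0.11 log units; within the scatter). With the same atoms joined differently, butyl and isobutyl cannot be told apart at this place, a reading that holds only for this pair, which carries the 4-hydroxyphenyl group. No further data bear on this result.

Still open, from the compounds shown here alone, is whether a longer chain such as hexyl, or an amine or a carboxylic acid in place of the butyl, would give a step beyond the scatter. For the compounds shown here, also open is whether the same branching reads alike with the 2-hydroxyphenyl group of compound 1, and compound 3 remains linked to this series by no single-place step.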